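Compound 3 to compound 4: exchange on the carbonyl

The source may report more compounds than this note shows. Statements on the series, on what has been measured and on what is new or still open speak of the compounds shown alone.

Measured in a functional assay (aorta) with Rattus norvegicus as the target; a higher number here means that more compound is needed for the effect, a lower number that less compound is needed:
- compound 1 `COc1ccc(-c2nc(/N=C(\N)NC(C)C)sc2-c2ccc(OC)cc2)cc1`: 9.1 uM
- compound 2 `COc1ccc(-c2nc(C(=O)N=C(N)N)sc2-c2ccc(OC)cc2)cc1`: > 100 uM (a limit)
- compound 3 `CCOC(=O)/C=C/c1nc(-c2ccc(OC)cc2)c(-c2ccc(OC)cc2)s1`: > 100 uM (a limit)

Compound 3 sits at the limit of > 100 uM in this assay, at which 2 of the 3 values shown sit, so it offers a limit and not a number. Compound 4 `COc1ccc(-c2nc(/C=C/C(=O)N3CCN(C)CC3)sc2-c2ccc(OC)cc2)cc1` carries 4-methylpiperazin-1-yl in place of ethoxy on a carbonyl carbon. For the measured compounds named here, no measured step covers this exchange. The large steps of an at least 10-fold higher number from compound 1 to compound 2 (1.04 log units; beyond the scatter) and an at least 10-fold higher number from compound 1 to compound 3 (1.04 log units; beyond the scatter) replace a group on an aromatic carbon and bear on it only indirectly. Going by the values given here, compound 1, at 9.1 uM, is the only measured number in this assay. A moderate move to a lower number is expected, though a result at the limit remains possible. The expected step is an at least 2.5-fold lower number from compound 3 to compound 4 (0.39 log units; beyond the scatter). The estimate for compound 4 is 40 uM, with an expected range of 8 uM to 200 uM.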

Compound 4, concentration for half-maximal effect: 20 uM
Compound 4: middle estimate off by 2.0-fold (0.30 log units), on the high side, within the range that was stated.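

In this assay, the carbonyl carbon on the double-bonded chain proves responsive: 4-methylpiperazin-1-yl in place of ethoxy gives an at least 5.0-fold lower number from compound 3 to compound 4 (0.69 log units; beyond the scatter). For the compounds shown here, the earlier steps replaced whole groups on an aromatic carbon, so this is the first reading of an exchange at the carbonyl alone. The true size of the step stays open-ended, since compound 3 gives only a limit: the limit of > 100 uM in this assay, at which 2 of the 4 values shown sit.

Still open, from the compounds shown here alone, is whether the step needs the 4-methylpiperazin-1-yl ring as a whole. A morpholine, a piperidine or an open-chain dimethylamine on the same carbonyl carbon would settle that.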